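Three limits and an untested trifluoromethyl analogue

This account rests on a few compounds, and the source may have more. Where it says the series, first, only, none or still open, it means among the compounds named here.

Compound 1 `CCOC(=O)c1oc2ccc(NS(=O)(=O)c3ccc(Br)cc3)cc2c1C`: > 40000 nM
Compound 2 `CCOC(=O)c1oc2ccc(NS(=O)(=O)c3ccc(Cl)cc3)cc2c1C`: > 40000 nM
Compound 3 `CCOC(=O)c1oc2ccc(N(Cc3ccccc3)S(=O)(=O)c3ccccc3Br)cc2c1C`: > 40000 nM

Within the data shown here, every value measured so far in a functional assay on HCT-116 cells (Homo sapiens) for inhibition, read by MTT assay, with a stated time of 72 h (a lower number here means a stronger inhibitor, a higher number a weaker inhibitor), is a limit of the assay, not a number, and all three sit at the same boundary (the limit of > 40000 nM in this assay, at which 3 of the 3 values shown sit). Among the measured compounds shown here, the one single-point step, a step that the two limits leave unreadable from compound 1 to compound 2, is therefore unreadable in size. Compound 3 stands at that limit with > 40000 nM, so nothing more than a boundary is known for it.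

Compound 4 `CCOC(=O)c1oc2ccc(N(Cc3ccccc3)S(=O)(=O)c3ccc(C(F)(F)F)cc3)cc2c1C` differs from compound 3 by 4-(trifluoromethyl)phenyl in place of 2-bromophenyl on a sulfonyl sulfur. For the measured compounds named here, no measured step gives a readable size for this change; the shared limit is all there is to lean on. Compound 4 is therefore expected to sit near the same boundary, estimated at 40000 nM with a range from 15000 nM to 100000 nM. The step thereby expected, a number no higher from compound 3 to compound 4 (the limit leaves the size open), is not larger than the scatter.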

Compound 4, half-maximal inhibitory concentration: 12700 nM
Compound 4: middle estimate off by 3.1-fold (0.50 log units), on the high side; measured number below the stated range.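

Replacing 2-bromophenyl with 4-(trifluoromethyl)phenyl on a sulfonyl sulfur gives, in this assay, an at least 3.1-fold lower number from compound 3 to compound 4 (0.49 log units; beyond the scatter), which shows that a change at this place can bring a compound off the boundary to a readable number. The size of this step remains a minimum, because compound 3 has only a limit: the limit of > 40000 nM in this assay, at which 3 of the 4 values shown sit.

From the compounds shown here alone, this single step changes both the substituent and its place on the aromatic ring, so the contribution of each remains open. Also open, going by these compounds, is how 4-bromophenyl, 2-(trifluoromethyl)phenyl or 4-aminophenyl would read on the same sulfonyl sulfur.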